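The source may report more compounds than this note shows. Statements on the series, on what has been measured and on what is new or still open speak of the compounds shown alone.

Measured in a functional assay on MCF7 cells (Homo sapiens) for inhibition, read by sulforhodamine B assay, with a stated time of 72 h (a lower number here means a stronger inhibitor of growth, a higher number a weaker inhibitor of growth), each as a limit rather than a number:

compound 1 `NC(=O)/C=C/c1ccncc1-c1ccc2ccccc2c1`: > 10000 nM.
compound 2 `Cn1ccc2cc(-c3cnccc3/C=C/C(=O)O)ccc21`: > 10000 nM.
compound 3 `CNC(=O)/C=C/c1ccncc1-c1ccc2c(cnn2C)c1`: > 10000 nM.

Compound 1 therefore stands at the limit of this assay, and no number has been obtained for it. The same holds for every value shown so far: the limit of > 10000 nM in this assay, at which 3 of the 3 values shown sit. Among the compounds with values here, no pair of measured compounds differs in one place only, so no measured step is available to set a scale.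

Compound 4 `CNC(=O)/C=C/c1ccncc1-c1ccc2ccccc2c1` is the unmeasured member of the series. Against compound 1 the change is methyl in place of hydrogen on an amide-type nitrogen. Compound 3 already carries the 2-(methylcarbamoyl)ethenyl group, on a different core, and in this assay compound 3 gives only a limit, > 10000 nM. With nothing in the measured set giving a number, there is no ground to expect the methyl on the amide nitrogen to move compound 4 off the limit.

The expected step from compound 1 to compound 4 is accordingly none beyond the scatter, a step that the limit leaves unreadable from compound 1 to compound 4, and most probably a further limit. For compound 4 the estimate in this assay is 20000 nM, with a range from 7000 nM to 60000 nM.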

Compound 4, concentration for 50% growth inhibition: 9340 nM
Estimate against measurement, compound 4: 2.1-fold (0.33 log units) above; measured number inside the range.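

In this assay, within the data shown here, compound 4 gives 9340 nM, the first actual number, so methyl in place of hydrogen on an amide-type nitrogen still allows a readable value on this core. The step reads as an at least 1.0-fold lower number from compound 1 to compound 4 (0.02 log units; that floor lies within the scatter); its starting point is only a limit, so this is a floor and not a size, and it does not establish a change beyond the scatter. The new number does not yet give the series a scale, and the limit still dominates the data: the limit of > 10000 nM in this assay, at which 3 of the 4 values shown sit.

Open, as far as these compounds go, is whether a longer chain on the same nitrogen, such as ethyl or propyl, or a second methyl on it, would give a lower number than compound 4 in this assay or return to the limit. Also open, from the compounds shown here alone, is whether replacing the whole carbamoyl group with a nitrile or an ester on the core of compound 4 would keep a readable value, and a series with more than one number would be needed to size any such step.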